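The source may report more compounds than this note shows. Statements on the series, on what has been measured and on what is new or still open speak of the compounds shown alone.

Measured compounds:
compound 1 `Cc1c(Cl)cc(NC(=O)Nc2ccc(OCCCN3CCCCC3)cc2)cc1Cl`, 18.2 nM
compound 2 `CC1CCCN1C1CCN(c2ccc(NC(=O)NC3CCCCC3)cc2)C1`, 4.1 nM
compound 3 `Cc1cc(N2CCC(N3CCCC3C)C2)ccc1NC(=O)NC1CCCCC1`, 4.6 nM

In an assay on CHO cells for displacement of a labelled ligand from histamine receptor H3 (Macaca mulatta), read by scintillation counting, with a stated time of 1 h (on this read-out higher numbers stand for weaker inhibition and lower numbers for stronger inhibition), compound 3 stands second highest of the three numbers; its nearest neighbour is compound 2, within the scatter, and its furthest is compound 1, beyond the scatter. Compound 4 `Cc1cc(N2CCC(N3CCCC3C)C2)ccc1NC(=O)N1CCN(C)CC1` differs from compound 3 by 4-methylpiperazin-1-yl in place of cyclohexylamino on a carbonyl carbon. Among the compounds with values here, the only measured step, a 1.1-fold higher number from compound 2 to compound 3 (0.05 log units; within the scatter), concerns a different place and does not bear on this change, so no measured step speaks to it. The writer therefore expects an uncertain, modest shift toward a higher number, a 3.3-fold higher number from compound 3 to compound 4 (0.51 log units; beyond the scatter), and estimates compound 4 at 15 nM, with a range from 3 nM to 80 nM.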

Compound 4, inhibition constant: 10.5 nM
Estimate against measurement, compound 4: 1.4-fold (0.15 log units) above; the measured number falls inside the stated range.
By their numbers in this assay, from the lowest: compounds 2 and 3 (each within the scatter of the next); then compounds 4 and 1 (each within the scatter of the next).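

In this assay, within the data shown here, the carbonyl carbon proves open to change: 4-methylpiperazin-1-yl in place of cyclohexylamino gives a 2.3-fold higher number from compound 3 to compound 4 (0.36 log units; beyond the scatter) and this modest step is the first measured at this position. The hydrogen-bond donor of cyclohexylamino is gone in compound 4, which still reads 10.5 nM in this series. Nothing measured here explains the step.

Still open, on these data alone, is whether the methyl on the piperazine matters, as piperazin-1-yl would show. Morpholin-4-yl or dimethylamino at the same carbon would show how far the step depends on the ring and its second nitrogen.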